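Removing the Methoxy Group from Compound 1

The compounds below may be only part of what the source reports. "The series", "measured", "known", "first", "only" and "open" are said of these compounds alone.

Compound 1 `COc1c(Nc2ccc(C#N)cc2Cl)ncnc1OC1C2COCC1CN(C(=O)OC1(C)CC1)C2` gives 99% in a functional assay on HEK293 cells for agonist activity at Glucose-dependent insulinotropic receptor (Mus musculus), read by fluorescence and cAMP accumulation, with a stated time of 30 min; on this read-out higher numbers stand for larger maximal responses and lower numbers for smaller maximal responses.
Compound 2 `COc1c(Nc2ccc(C#N)cc2F)ncnc1OC1C2COCC1CN(C(=O)OC1(C)CC1)C2` gives 116% in this assay.
Compound 3 `Cc1c(Nc2ccc(C#N)cc2Cl)ncnc1OC1CC2COCC(C1)N2C(=O)OC(C)(C)C` gives 34%; 57% (2 entries) in this assay.

Among the compounds with a single number, compound 1 stands lowest: the only measured step, a number 17 percentage points higher from compound 1 to compound 2 (beyond the scatter), comes from fluoro in place of chloro on an aromatic carbon and lifts the maximal response. Compound 3 was run more than once, (the several entries of compound 3 in this assay, 34%; 57% (2 entries)), and both of its readings fall under those of compound 1 and compound 2.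

Compound 4 `CC1(OC(=O)N2CC3COCC(C2)C3Oc2cc(Nc3ccc(C#N)cc3Cl)ncn2)CC1` differs from compound 1 in one place: hydrogen in place of methoxy on an aromatic carbon. Among the measured compounds shown here, no measured step touches this position. The step of a number 17 percentage points higher from compound 1 to compound 2 (beyond the scatter) alters the halogen on the other ring, and compound 3 differs from compound 1 in several places at once, so its lower readings cannot be tied to the group on the core alone. With no direct guide, compound 4 is expected to give a maximal response near that of compound 1, perhaps slightly lower; the estimate is 85% with a range from 50% to 115%, which means an expected step of a number 14 percentage points lower from compound 1 to compound 4 (beyond the scatter).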

Compound 4, largest response reached (reported as percent of maximum), in percent of the reference or control that the assay uses: 105%
Compound 4: the middle estimate sits 20 percentage points below what was measured, and the stated range covers the measured number.
By their numbers in this assay, from the lowest: compounds 1 and 4 (each within the scatter of the next); then compound 2.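

Hydrogen in place of methoxy on this aromatic carbon gives a number 6 percentage points higher from compound 1 to compound 4 (within the scatter) in this assay, so the maximal responses of the two compounds cannot be told apart. Among the compounds shown here, this is the first direct reading at this position: with the rest of compound 1 kept, the methoxy group can be replaced by hydrogen without a measurable effect on maximal response, whereas the halogen change gave a number 17 percentage points higher from compound 1 to compound 2 (beyond the scatter). Nothing measured here explains why the response stays level at this position.

On these data alone, only hydrogen and methoxy can be compared at this position, so it remains open whether an amine or an ethoxy chain there would also leave the maximal response level. Also open, as far as these compounds go, is whether hydrogen in place of methoxy would behave the same way in compound 2, which carries fluoro on the other ring.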